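Halogen pattern on the benzyl group and protein inhibition

The source may hold more compounds than are shown below. What is called first, only, known or untested is meant among the compounds shown, and "the series" means these compounds.

Compound 1 `COc1ccc(S(=O)(=O)N(Cc2ccc(Br)cc2)[C@H](C)C(=O)NO)cc1`: 37 nM
Compound 2 `COc1ccc(S(=O)(=O)N(Cc2ccc(Cl)c(Cl)c2)[C@H](C)C(=O)NO)cc1`: 120 nM

In an assay on isolated protein for inhibition of bone morphogenetic protein 1 (Homo sapiens) (a higher number here means a weaker inhibitor, a lower number a stronger inhibitor), compound 2 holds the higher of the two numbers; compound 1 lies below it by a 3.2-fold higher number from compound 1 to compound 2 (0.51 log units; beyond the scatter). Compound 3 `COc1ccc(S(=O)(=O)N(Cc2cccc(Br)c2)[C@H](C)C(=O)NO)cc1` differs from compound 2 by 3-bromophenyl in place of 3,4-dichlorophenyl on a saturated chain carbon bound to a sulfonamide nitrogen. Within the data shown here, the one measured step that bears on this, a 3.2-fold higher number from compound 1 to compound 2 (0.51 log units; beyond the scatter), shows that going from 4-bromophenyl to 3,4-dichlorophenyl raised the number modestly. Since compound 3 again carries a single bromine on that ring, a modest fall is expected for compound 3, a 2.2-fold lower number from compound 2 to compound 3 (0.34 log units; beyond the scatter). Compound 3 is estimated at 55 nM, within 20 nM to 160 nM.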

Compound 3, half-maximal inhibitory concentration: 93 nM
Beside the measured number, compound 3's estimate is 1.7-fold (0.23 log units) below it; low and high end bracket the measured number.
By their numbers in this assay, from the lowest: compound 1; then compounds 3 and 2 (each within the scatter of the next).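

With a single bromine kept on the ring, its placement matters in this assay: 3-bromophenyl in place of 4-bromophenyl gives (a 2.5-fold higher number from compound 1 to compound 3 (0.40 log units; beyond the scatter)). Exchanging 3,4-dichlorophenyl for 3-bromophenyl gives (a 1.3-fold lower number from compound 2 to compound 3 (0.11 log units; within the scatter)), so compound 2 and compound 3 cannot be told apart, and carrying one bromine is not enough to match compound 1. No measurement at hand accounts for these differences. Still open, on these data alone, is how 4-chlorophenyl would read at this place, and whether a ring carrying an amine or a carboxylic acid would fit the same picture.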